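Chloro to bromo exchange: from compound 2 to compound 3

The compounds below may be only part of what the source reports. "The series", "measured", "known", "first", "only" and "open" are said of these compounds alone.

Measured so far:
compound 1 `COc1cc(CNC(=S)NC(CCc2ccc(C(C)(C)C)cc2)COC(=O)C(C)(C)C)cc(Br)c1O`: 143 nM
compound 2 `COc1cc(CNC(=S)NC(CCc2ccc(C)c(C)c2)COC(=O)C(C)(C)C)cc(Cl)c1O`: 86 nM

In an assay on CHO cells for displacement of a labelled ligand from transient receptor potential cation channel subfamily V member 1 (Rattus norvegicus) (a lower number here means a stronger inhibitor, a higher number a weaker inhibitor), compound 2 gives 86 nM, the lowest of the two numbers shown. Compound 1 gives 143 nM in this assay, and the gap between compound 2 and compound 1 is within the scatter, so no order between the two can be stated.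

Compound 3 `COc1cc(CNC(=S)NC(CCc2ccc(C)c(C)c2)COC(=O)C(C)(C)C)cc(Br)c1O` has not been measured. It differs from compound 2 in one place: bromo in place of chloro on an aromatic carbon. Going by the values given here, compound 1 carries the same bromo at this carbon but also a different group on the other ring, so the two measured compounds do not isolate this exchange and no step for it is available.

The change is one heavy atom for one heavy atom, with no change in donors, acceptors or charge. The expectation is a step from compound 2 to compound 3 of no more than the scatter, in either direction. Compound 3 is expected to give about 100 nM in this assay, within 45 nM to 220 nM. This corresponds to an expected step of a 1.2-fold higher number from compound 2 to compound 3 (0.07 log units; within the scatter).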

Compound 3, inhibition constant: 102 nM
Compound 3: the middle estimate sits 1.0-fold (0.01 log units) below what was measured; the measured number falls inside the stated range.
By their numbers in this assay, from the lowest: compounds 2, 3 and 1 (each within the scatter of the next).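

In this assay the exchange of chloro for bromo on the aromatic carbon ortho to a hydroxy group can now be read on its own, and it gives a 1.2-fold higher number from compound 2 to compound 3 (0.07 log units; within the scatter) with the 3,4-dimethylphenyl group held constant, so the two halogens are not separated at this position. With bromo held constant, the other place can be read too: 3,4-dimethylphenyl in place of 4-(tert-butyl)phenyl gives a 1.4-fold lower number from compound 1 to compound 3 (0.15 log units; within the scatter) and so does not separate these two groups in this assay either. Nothing measured here offers a reason for either result.

As far as these compounds go, the halogen exchange has been read only with the 3,4-dimethylphenyl group, so whether it behaves the same way with 4-(tert-butyl)phenyl remains open. Also open is whether this position tolerates groups of a different kind, since the compounds shown carry only chloro and bromo there and leave hydrogen, fluoro, nitrile or an amine at this carbon untested in this series.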